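Trimming the amide substituent of a diaryl urea

This account rests on a few compounds, and the source may have more. Where it says the series, first, only, none or still open, it means among the compounds named here.

Three diaryl ureas sharing one core were tested in a functional assay on A-375 cells (Homo sapiens) for inhibition, read by MTT assay, with a stated time of 120 h; on this read-out lower numbers stand for stronger inhibition and higher numbers for weaker inhibition. Compound 1 `C/C(=C\c1ccc(NC(=O)Nc2ccc(Cl)c(C(F)(F)F)c2)cc1)C(=O)NC(C)c1ccccc1` reached only the assay limit, > 50000 nM. Compound 3 `CC(NC(=O)CCc1ccc(NC(=O)Nc2ccc(Cl)c(C(F)(F)F)c2)cc1)c1ccccc1` likewise gave a limit, > 50000 nM. Among the compounds with values here, compound 2 `CC(NC(=O)c1cccc(-c2ccc(NC(=O)Nc3ccc(Cl)c(C(F)(F)F)c3)cc2)c1)c1ccccc1` is the single compound with a number, 5170 nM, and so stands on its own, while the other two values sit at the limit of > 50000 nM in this assay, at which 2 of the 3 values shown sit. Compound 4 `CNC(=O)c1cccc(-c2ccc(NC(=O)Nc3ccc(Cl)c(C(F)(F)F)c3)cc2)c1` differs from compound 2 by methyl in place of 1-phenylethyl on an amide-type nitrogen. Within the data shown here, no measured pair shows a change of this kind, so its size is uncertain. The step from compound 2 to compound 4 is expected to weaken inhibition beyond the scatter, a 2.9-fold higher number from compound 2 to compound 4 (0.46 log units; beyond the scatter). Compound 4 is estimated at 15000 nM, between 5000 nM and 50000 nM.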

Compound 4, half-maximal inhibitory concentration: 46500 nM
Beside the measured number, compound 4's estimate is 3.1-fold (0.49 log units) below it; the range from low to high includes it.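

Within the data shown here, on the amide-type nitrogen, the earlier compounds offered no single-place comparison, and here this assay gives the first: methyl in place of 1-phenylethyl brings a 9.0-fold higher number from compound 2 to compound 4 (0.95 log units; beyond the scatter). So the substituent at this nitrogen matters for inhibition in this pair, and little room remains on this read-out: the limit of > 50000 nM in this assay, at which 2 of the 4 values shown sit. The step removes the aromatic ring and the chain together, so it cannot separate the two. On these data alone, whether a benzyl group, a cyclohexyl group or a longer alkyl chain on this nitrogen would keep inhibition stays open.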